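Cytotoxicity notes: amine substituent exchange, compound 3 to compound 4

The source may hold more compounds than are shown below. What is called first, only, known or untested is meant among the compounds shown, and "the series" means these compounds.

Compound 3 `Cc1ccc2[nH]c(=O)c(CN(Cc3ccc(C(C)(C)C)cc3)[C@H](CO)c3ccccc3)cc2c1` stands in a toxicity assay on MDCK cells (Canis lupus familiaris) for cytotoxicity, read by crystal violet staining, with a stated time of 48 h (a higher number here means that more compound is tolerated, a lower number that less compound is tolerated), only at a limit, > 10000 nM. Going by the values given here, the two values shown beside it are limits as well, so no compound in this set has a number. Compound 1 `Cc1ccc2[nH]c(=O)c(CN(Cc3ccc(OCC(=O)O)cc3)Cc3ccc(C(C)(C)C)cc3)cc2c1` sits in this assay at > 10000 nM, a limit. Compound 2 `CCCCOc1ccc(CN(Cc2ccc(C(C)(C)C)cc2)Cc2cc3cc(C)ccc3[nH]c2=O)cc1` sits in this assay at > 5000 nM, also a limit. Compound 4 `COc1ccc(C(C)N(Cc2ccc(C(C)(C)C)cc2)Cc2cc3cc(C)ccc3[nH]c2=O)cc1Cl` is not yet measured; it differs from compound 3 by 1-(3-chloro-4-methoxyphenyl)ethyl in place of 2-hydroxy-1-phenylethyl on an amine nitrogen. Among the compounds with values here, two measured steps touch the same amine nitrogen: a step that the two limits leave unreadable from compound 1 to compound 3 and a step that the two limits leave unreadable from compound 2 to compound 3. The third, a step that the two limits leave unreadable from compound 1 to compound 2, lies elsewhere in the molecule. None of them gives a readable size, since the limit of > 10000 nM in this assay, at which 2 of the 3 values shown sit, and the limit of > 5000 nM in this assay, at which 1 of the 3 values shown sits, cap every value shown. A readable step in this assay beyond the scatter can therefore not be drawn from the measured pairs in either direction, and the working expectation is that compound 4 again reaches the limit rather than a number. Compound 4 is estimated in this assay at 10000 nM, within 3000 nM to 30000 nM. The step of a number no higher from compound 3 to compound 4 (the limit leaves the size open) that this estimate implies is expected to be close to none.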

Compound 4, half-maximal cytotoxic concentration: > 10000 nM
Compound 4: only a limit was reported; the forecaster's own chance of this, stated with the estimate: 75%; the middle value lies on the limit itself.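

In this assay compound 4 gives > 10000 nM, a limit and not a number. The steps to compound 4 from compound 1, compound 2 and compound 3 cannot be read, because every value shown is a limit: the limit of > 10000 nM in this assay, at which 3 of the 4 values shown sit.

The compounds shown leave open whether any amine nitrogen substituent here gives a numerical cytotoxic concentration, and how far these compounds lie apart.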